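A few compounds are considered here, and "the series" means these few. Any claim that something is new, unique, unknown or untested is made for them only; others in the source may bear on it.

Measured compounds:
- compound 1, `CCCOCNc1n[n+]([O-])c2cc(OC)ccc2[n+]1[O-]`, in a functional assay on PC-3 cells (Homo sapiens) for cytotoxicity, read by MTT assay, with a stated time of 72 h (on this read-out higher numbers stand for weaker inhibition and lower numbers for stronger inhibition), compound 1 gives 6570 nM
- compound 2, `COc1ccc2c(c1)[n+]([O-])nc(NCOC(C)c1ccccc1)[n+]2[O-]`, compound 2 gives 4140 nM
- compound 3, `CC(OCNc1n[n+]([O-])c2ccccc2[n+]1[O-])c1ccccc1`, compound 3 gives 6080 nM

Compound 2 holds the lowest of the three numbers, but its neighbours sit close: a 1.6-fold lower number from compound 1 to compound 2 (0.20 log units; within the scatter), and a 1.5-fold higher number from compound 2 to compound 3 (0.17 log units; within the scatter), so no ordering among the three can be read from these values.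

Compound 4, `CCCCCOCNc1n[n+]([O-])c2cc(OC)ccc2[n+]1[O-]`, differs from compound 2 in one place: pentyl in place of 1-phenylethyl on an oxygen on a saturated carbon. Among the measured compounds shown here, the only measured step that bears on this change is the one from compound 1 to compound 2, where a propyl chain was exchanged for 1-phenylethyl at the same oxygen and the number moved only within the scatter. Returning to a plain chain, now pentyl, is expected to do no more than undo that small shift. Compound 4 is therefore expected to show a step of a 1.3-fold higher number from compound 2 to compound 4 (0.12 log units; within the scatter), which is within the scatter. Compound 4 is estimated at 5500 nM, with a range from 2500 nM to 12000 nM.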

Compound 4, half-maximal inhibitory concentration: 3630 nM
The estimate for compound 4 lay 1.5-fold (0.18 log units) above the measured number, within the range that was stated.
By their numbers in this assay, from the lowest: compounds 4, 2, 3 and 1 (each within the scatter of the next).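

In this assay, the exchange at this oxygen gives a 1.1-fold lower number from compound 2 to compound 4 (0.06 log units; within the scatter) and so shows that a plain pentyl chain, with no ring and fewer heavy atoms, stays within the scatter of 1-phenylethyl. Extending the chain from propyl, with ethyl in place of hydrogen on the saturated chain carbon, gives a 1.8-fold lower number from compound 1 to compound 4 (0.26 log units; within the scatter) and so shows that, among propyl, pentyl and 1-phenylethyl on the methoxy-bearing core, no step at this oxygen leaves the scatter. No measurement at hand offers an explanation for these values.

The compounds shown leave open whether an amine, a carboxylic acid or a chain longer than pentyl on this oxygen would move the number beyond the scatter. They also leave open how pentyl compares with 1-phenylethyl with hydrogen in place of methoxy on the aromatic carbon, a change shown only for 1-phenylethyl.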